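Para-substituent swap on the shared core: compound 3 to compound 4

The source may hold more compounds than are shown below. What is called first, only, known or untested is meant among the compounds shown, and "the series" means these compounds.

Measured so far in an ADME assay on Vero cells (Chlorocebus sabaeus) for cytotoxicity, read by neutral red uptake, tested at 787 ug/mL; a higher number here means a weaker effect of the compound at the concentration tested, a lower number a stronger effect:
compound 1 `O=C1CSC(c2cccc(O)c2)N1CCN1CCCCC1` gives 60%
compound 2 `O=C1CSC(c2ccc([N+](=O)[O-])cc2)N1CCN1CCCCC1` gives 21%
compound 3 `Cc1ccc(C2SCC(=O)N2CCN2CCCCC2)cc1` gives 17%

Compound 3 holds the lowest of the three numbers. Its nearest neighbour is compound 2, which lies within the scatter of it; compound 1 is furthest off, with the step of a number 43 percentage points lower from compound 1 to compound 3 (beyond the scatter).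

The next compound, compound 4 `O=C1CSC(c2ccc(Cl)cc2)N1CCN1CCCCC1`, is not yet measured. It differs from compound 3 in one place: chloro in place of methyl on an aromatic carbon.

The step that bears on this change is a number 4 percentage points lower from compound 2 to compound 3 (within the scatter): a swap of one small group for another on the same aromatic carbon, which left the number where it was. The large step from compound 1 to compound 3 involves a different position and a different group and is set aside. On that basis the change from methyl to chloro is expected to give no step beyond the scatter, a number 3 percentage points higher from compound 3 to compound 4 (within the scatter).

Compound 4 is therefore estimated at 20% in this assay, with a range of 8% to 40%.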

Compound 4, a percentage reported as activity, at one concentration (the size of the read-out at that concentration, not a potency): 15%
Beside the measured number, compound 4's estimate is 5 percentage points above it; the range from low to high includes it.
By their numbers in this assay, from the lowest: compounds 4, 3 and 2 (each within the scatter of the next); then compound 1.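

In this assay chloro in place of methyl on this aromatic carbon, para to a large group, gives a number 2 percentage points lower from compound 3 to compound 4 (within the scatter) and chloro in place of nitro gives a number 6 percentage points lower from compound 2 to compound 4 (within the scatter) on the same carbon, so methyl, nitro and chloro at this position cannot be told apart in these numbers. The 3-hydroxyphenyl group of compound 1 still stands apart from this cluster, with a number 45 percentage points lower from compound 1 to compound 4 (beyond the scatter) as a second large step alongside the one already seen for the 4-methylphenyl group. No measured property is at hand to account for either the cluster or the large step.

From the compounds shown here alone, whether a 4-hydroxyphenyl group would fall with compounds 2, 3 and 4 or with compound 1 remains open, so the hydroxy group and its place on the ring cannot yet be separated. Also open, going by these compounds, is what an amine or a carboxylic acid on this aromatic carbon would do to the number.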